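Hydroxy to amino on a chlorophenol-type core: two pairs

The source may report more compounds than this note shows. Statements on the series, on what has been measured and on what is new or still open speak of the compounds shown alone.

Measured so far:
compound 1, `Cn1cncc1-c1cc(Cl)ccc1O`: 17000 nM
compound 2, `Cn1cncc1-c1cc(Cl)ccc1N`: 1200000 nM
compound 3, `Oc1ccc(Cl)cc1-n1ccnc1`: 2100 nM

In an assay on cells for inhibition of Indoleamine 2,3-dioxygenase 1 (Homo sapiens), read by HPLC, with a stated time of 20 min (a lower number here means a stronger inhibitor, a higher number a weaker inhibitor), compound 3 gives the lowest of the three numbers, compound 1 sits well above it, and compound 2 lies far above both. The difference between the core of compound 1 and the core of compound 3 is not broken down here.

Within the first pair the change amino in place of hydroxy on an aromatic carbon gave a 71-fold higher number from compound 1 to compound 2 (1.85 log units; beyond the scatter), a large loss on the measured scale.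

Compound 4, `Nc1ccc(Cl)cc1-n1ccnc1`, is not yet measured. It arises from compound 3 by amino in place of hydroxy on an aromatic carbon. Among the compounds with values here, this is the same kind of change as the one from compound 1 to compound 2, not the same: the place differs in that, in compound 3, the group ortho to the exchanged position has 5 heavy atoms, whereas in compound 1 that group has 6 heavy atoms. Within the data shown here, only the one earlier instance exists to lean on, so the expectation is an extrapolation from a single pair.

For compound 4 the step is expected to be about a 62-fold higher number from compound 3 to compound 4 (1.79 log units; beyond the scatter), resting on the same exchange having produced a 71-fold higher number from compound 1 to compound 2 (1.85 log units; beyond the scatter). Compound 4 is therefore estimated at 130000 nM, with a plausible span from 30000 nM to 500000 nM.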

Compound 4, half-maximal inhibitory concentration: 88000 nM
The estimate for compound 4 lay 1.5-fold (0.17 log units) above the measured number; the measured number falls inside the stated range.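

In this assay, amino in place of hydroxy on an aromatic carbon again brings a heavy loss, with a 42-fold higher number from compound 3 to compound 4 (1.62 log units; beyond the scatter) on the core of compound 3. Within the data shown here, this rests on two pairs in a single assay, so it shows only that the change carries between these two cores; it does not show why the amino compounds lose so much, or that a core outside these two would respond in the same way. Within those limits, the size of the loss holds from one core to the other: the same change on two cores in this assay, a 71-fold higher number (1.85 log units; beyond the scatter) from compound 1 to compound 2 and a 42-fold higher number (1.62 log units; beyond the scatter) from compound 3 to compound 4, 1.7-fold (0.23 log units) apart, within the scatter of two such steps

On these data alone, the exchanged place is represented only by hydroxy and amino, so a methoxy group or a fluoro group there remains open, as does whether the same loss would appear with a bromo group in place of the chloro group. Also open, as far as these compounds go, is how the two cores compare when separated from this exchange, for instance with a methyl group moved to another carbon of the imidazole-bearing part of compound 3.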